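Swapping a Pyrazine for a Dimethoxyphenyl on the Ring Nitrogen

This account rests on a few compounds, and the source may have more. Where it says the series, first, only, none or still open, it means among the compounds named here.

The measured compounds, all tested in a functional assay on HOS-TE85 cells (Homo sapiens) for inhibition, read by CCK-8 assay, with a stated time of 72 h; a higher number here means a weaker inhibitor, a lower number a stronger inhibitor:
- compound 1, `O=C(NCCCCc1ccccc1)c1cccc(C2SCC(=O)N2c2cnccn2)c1`, gives > 1000 nM
- compound 2, `O=C(NCCCCc1ccccc1)c1cc(F)cc(C2SCC(=O)N2c2ccccn2)c1`, gives 14.2 nM
- compound 3, `COc1ccccc1N1C(=O)CSC1c1cccc(C(=O)NCCCCn2cccn2)c1`, gives 91.7 nM

Compound 1 stands at the bottom of this short set: its value in this assay is only a limit of the assay, not a number, as recorded in the limit of > 1000 nM in this assay, at which 1 of the 3 values shown sits. Compound 2 and compound 3 both give real numbers, with compound 2 the lower of the two.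

The new compound 4, `COc1cccc(OC)c1N1C(=O)CSC1c1cccc(C(=O)NCCCCc2ccccc2)c1`, is compound 1 with one change: 2,6-dimethoxyphenyl in place of pyrazin-2-yl on an amide-type nitrogen in a ring. Compound 3 already carries a methoxy-bearing phenyl on the same ring nitrogen and gives 91.7 nM in this assay. Compound 1 gives only a limit of the assay there. Within the data shown here, no measured pair isolates this exact change, so the size of the step can only be guessed from those two values.

The step is expected to be a clear gain in potency: an at least 8.3-fold lower number from compound 1 to compound 4 (0.92 log units; beyond the scatter) is the estimated move. Compound 4 is expected to give about 120 nM in this assay, likely between 25 nM and 600 nM.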

Compound 4, half-maximal inhibitory concentration: > 1000 nM
Compound 4: no number, only a limit; the forecaster's own chance of this, stated with the estimate: 15%; middle value at least 8.3-fold (0.92 log units) from the limit.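

Compound 1 and compound 4 each give only a limit of the assay, not a number, so no step can be read between them: the limit of > 1000 nM in this assay, at which 2 of the 4 values shown sit.

The compounds shown leave open which of pyrazin-2-yl and 2,6-dimethoxyphenyl gives the stronger inhibitor in this assay, and by how much.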